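The compounds below may be only part of what the source reports. "The series", "measured", "known", "first", "only" and "open" are said of these compounds alone.

In an ADME assay on microsomes from liver (Rattus norvegicus) for metabolic stability, read by LC-MS, using NADPH, with a stated time of 30 min, tested at 1 uM (a higher number here means faster removal of the compound, a lower number slower removal), compound 1 `Cc1cc(-c2ccc([C@H](C)Nc3nccc(N4C(=O)OC[C@@H]4C(C)C)n3)nc2)ccn1` gives 68 mL.min-1.g-1, compound 2 `Cc1cc(-c2ccnc(C(F)(F)F)c2)cnc1[C@H](C)Nc1nccc(N2C(=O)OC[C@@H]2C(C)C)n1` gives 128 mL.min-1.g-1 and compound 3 `CC(C)[C@H]1COC(=O)N1c1ccnc(N[C@@H](C)c2ccc(-c3ccnc(C(F)(F)F)c3)cn2)n1` gives 101 mL.min-1.g-1. Compound 3 thus stands within the scatter of both other compounds. Compound 4 `CC(C)[C@H]1COC(=O)N1c1ccnc(N[C@@H](C)c2ccc(-c3ccnc(C(C)(C)C)c3)cn2)n1` differs from compound 3 in one place: tert-butyl in place of trifluoromethyl on an aromatic carbon. This puts tert-butyl in place of trifluoromethyl on an aromatic carbon. The closest measured change is a 1.5-fold higher number from compound 1 to compound 3 (0.17 log units; within the scatter), where trifluoromethyl replaces methyl at that same place. A change elsewhere, a 1.3-fold lower number from compound 2 to compound 3 (0.10 log units; within the scatter), is equally small. For the measured compounds named here, no measured compound carries tert-butyl, so the estimate stays cautious. The expected step is a 1.2-fold higher number from compound 3 to compound 4 (0.07 log units; within the scatter), which would not go beyond the scatter. Compound 4 is estimated at 120 mL.min-1.g-1, with an expected range from 65 mL.min-1.g-1 to 220 mL.min-1.g-1.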

Compound 4, intrinsic clearance in microsomes: 235 mL.min-1.g-1
Beside the measured number, compound 4's estimate is 2.0-fold (0.29 log units) below it, outside the stated range (above it).
By their numbers in this assay, from the lowest: compounds 1, 3, 2 and 4 (each within the scatter of the next, the first and the last beyond it).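

In this assay tert-butyl in place of trifluoromethyl gives a 2.3-fold higher number from compound 3 to compound 4 (0.37 log units; beyond the scatter) and tert-butyl in place of methyl gives a 3.5-fold higher number from compound 1 to compound 4 (0.54 log units; beyond the scatter) at the place next to the ring nitrogen. Both steps lie beyond the scatter, whereas the earlier swap of methyl for trifluoromethyl there stayed within it, so this position can register a change of group after all. As far as these compounds go, whether a cyclopropyl ring, a methoxy group or an amine at this place would give a lower number than methyl stays open. Nothing measured here offers an explanation of these steps.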